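A few compounds are considered here, and "the series" means these few. Any claim that something is new, unique, unknown or untested is made for them only; others in the source may bear on it.

Of the compounds shown here, three built on one shared core have been tested in a functional assay on A549 cells (Homo sapiens) for cytotoxicity, read by MTT assay, with a stated time of 72 h; a higher number here means a weaker inhibitor, a lower number a stronger inhibitor. Compound 1 `C#CCn1cc(C(=O)NC(CC(=O)Nc2ccccc2)c2ccccc2)c(=O)c2cc(F)c(Cl)nc21` gives only the limit of > 10000 nM, not a number. Compound 2 `C#CCn1cc(C(=O)NC(CC(=O)Nc2ccccn2)c2ccccc2)c(=O)c2ccc(Cl)nc21` likewise reaches only the limit of > 10000 nM. Going by the values given here, compound 3 `C#CCn1cc(C(=O)NC(CC(=O)NC2CCCC2)c2ccccc2)c(=O)c2ccc(Cl)nc21` is the one compound with a measured number, 9500 nM in this assay. It thus stands as the sole figure among the three, while the other two sit at the limit (the limit of > 10000 nM in this assay, at which 2 of the 3 values shown sit). Among the compounds with values here, the single one-point step, an at least 1.0-fold lower number from compound 2 to compound 3 (0.02 log units; that floor lies within the scatter), lies within the scatter.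

Compound 4 `C#CCn1cc(C(=O)NC(CC(=O)NC2CCCC2)c2ccccc2)c(=O)c2cc(F)c(Cl)nc21` differs from compound 3 by fluoro in place of hydrogen on an aromatic carbon. Within the data shown here, no measured step covers this exchange on its own. Compound 1, which carries the same fluoro group together with a different amide, sits at the limit in this assay. Because all three values cluster around the limit (the limit of > 10000 nM in this assay, at which 2 of the 3 values shown sit), the expected step for compound 4 in this assay is a 1.1-fold higher number from compound 3 to compound 4 (0.02 log units; within the scatter), that is, nothing beyond the scatter. Compound 4 is therefore estimated at 10000 nM, with a range from 5000 nM to 20000 nM.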

Compound 4, half-maximal inhibitory concentration: 6100 nM
Estimate against measurement, compound 4: 1.6-fold (0.21 log units) above; low and high end bracket the measured number.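

In this assay, the fluoro group at this position, ortho to a chloro group and two atoms from the ring nitrogen, can now be read on its own: a 1.6-fold lower number from compound 3 to compound 4 (0.19 log units; within the scatter), so adding this one atom in place of hydrogen shows no change beyond the scatter. Compound 1 gives > 10000 nM, which is a limit and not a number. With the fluoro group present in both compounds, cyclopentyl in place of phenyl on the amide-type nitrogen gives an at least 1.6-fold lower number from compound 1 to compound 4 (0.21 log units; that floor lies within the scatter), so this exchange can be read only as a floor: the limit of > 10000 nM in this assay, at which 2 of the 4 values shown sit.

On these data alone, it remains open whether bromo, a methoxy group or an amine at this position would move the number beyond the scatter. As far as these compounds go, how a longer chain on the amide-type nitrogen would read is also open.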